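This account rests on a few compounds, and the source may have more. Where it says the series, first, only, none or still open, it means among the compounds named here.

Measured so far in a functional assay for inhibition, with Homo sapiens as the target; a higher number here means a weaker inhibitor, a lower number a stronger inhibitor:

Compound 1 `C=C=Cn1nc(C)c2c(C)nc(CCC)n2c1=O` gives > 48000 nM, a limit of the assay rather than a number.

Compound 2 `CCCc1nc(C)c2c(C)nn(Cc3ccccc3)c(=O)n12` gives > 48000 nM, likewise a limit of the assay and not a number.

Compound 2 therefore stands at no defined point in this assay: all that is known of it is a limit. Among the compounds with values here, the only measured step, a step that the two limits leave unreadable from compound 1 to compound 2, cannot be read, because both of its endpoints sit at the limit of > 48000 nM in this assay, at which 2 of the 2 values shown sit. Nothing in the measured pair shows whether the group on the aromatic nitrogen moves potency at all.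

Compound 3 `CCCc1nc(C)c2c(C)nn(CC(O)CO)c(=O)n12` differs from compound 2 by 1,2-dihydroxyethyl in place of phenyl on a saturated chain carbon bound to an aromatic nitrogen. Within the data shown here, the single measured step bears on the same position but has no readable size, so it gives no direction to carry forward. With both measured compounds at the limit, compound 3 is expected to remain at or near that limit as well, and the expected step that the limit leaves unreadable from compound 2 to compound 3 is none beyond the scatter. In this assay compound 3 is therefore estimated at 60000 nM, within a range from 20000 nM to 200000 nM, and most likely reported only as a limit.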

Compound 3, half-maximal inhibitory concentration: > 48000 nM
Compound 3 was reported as a limit (the forecaster's own chance of this, stated with the estimate: 85%); the middle value does not contradict the limit.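

Neither step to compound 3, from compound 1 or from compound 2, can be read in this assay, because all three compounds sit at the same limit of the assay: the limit of > 48000 nM in this assay, at which 3 of the 3 values shown sit.

The compounds shown leave open whether propa-1,2-dien-1-yl, benzyl or 2,3-dihydroxypropyl on the aromatic nitrogen moves potency at all, and in which direction.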